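Aryl versus benzyl on the triazole nitrogen

A few compounds are considered here, and "the series" means these few. Any claim that something is new, unique, unknown or untested is made for them only; others in the source may bear on it.

Measured so far:
compound 1 `CC(C)n1ncc2c(C(=O)NCc3cn(-c4cccc(Br)c4)nn3)cccc21` — 33700 nM
compound 2 `Cc1ccccc1-n1cc(CNC(=O)c2cccc3c2cnn3C(C)C)nn1` — 19200 nM
compound 3 `COc1ccc(-n2cc(CNC(=O)c3cccc4c3cnn4C(C)C)nn2)cc1` — 34300 nM

In a functional assay on PC-3 cells (Homo sapiens) for inhibition, read by MTT assay, with a stated time of 72 h (a lower number here means a stronger inhibitor, a higher number a weaker inhibitor), compound 1 gives the second highest of the three numbers; the steps of a 1.0-fold higher number from compound 1 to compound 3 (0.01 log units; within the scatter) and a 1.8-fold lower number from compound 1 to compound 2 (0.24 log units; within the scatter) both lie within the scatter, so the three compounds are not separated by this assay. Compound 4 `CC(C)n1ncc2c(C(=O)NCc3cn(Cc4ccccc4)nn3)cccc21` differs from compound 1 in one place: benzyl in place of 3-bromophenyl on an aromatic nitrogen. For the measured compounds named here, the steps that bear on this position, a 1.8-fold lower number from compound 1 to compound 2 (0.24 log units; within the scatter), a 1.0-fold higher number from compound 1 to compound 3 (0.01 log units; within the scatter) and a 1.8-fold higher number from compound 2 to compound 3 (0.25 log units; within the scatter), all swap one aryl group for another and none passes the scatter; no measured step exchanges an aryl for a benzyl group. The expected step is therefore a 1.1-fold lower number from compound 1 to compound 4 (0.05 log units; within the scatter), none beyond the scatter. Compound 4 is estimated at 30000 nM, range 12000 nM to 75000 nM.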

Compound 4, half-maximal inhibitory concentration: 4420 nM
Estimate against measurement, compound 4: 6.8-fold (0.83 log units) above, and the stated range ends above it.
By their numbers in this assay, from the lowest: compound 4; then compounds 2, 1 and 3 (each within the scatter of the next).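

In this assay this aromatic nitrogen responds to the kind of group it carries: the aryl exchanges stayed within the scatter, but benzyl separates compound 4 from all three aryl compounds (a 7.6-fold lower number from compound 1 to compound 4 (0.88 log units; beyond the scatter)) and (a 7.8-fold lower number from compound 3 to compound 4 (0.89 log units; beyond the scatter)) and (a 4.3-fold lower number from compound 2 to compound 4 (0.64 log units; beyond the scatter)). Benzyl and 3-bromophenyl have the same heavy-atom count, so the step from compound 1 comes without any change in that count. Nothing available here bears on the origin of this step.

Open: whether a longer chain such as phenethyl, or a benzyl group carrying bromine or methoxy, keeps the lower number.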